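The compounds below may be only part of what the source reports. "The series", "measured", "known", "first", "only" and "open" are said of these compounds alone.

Measured in a functional assay on MCF7 cells (Homo sapiens) for antiproliferative activity, read by MTT assay, with a stated time of 72 h; a higher number here means a weaker inhibitor of growth, a lower number a stronger inhibitor of growth:
compound 1, `Cn1nc(-c2ccnc(Nc3ccc(O)cc3)n2)c2ccccc21`, gives 8910 nM
compound 2, `CCn1nc(-c2ccnc(Nc3ccc(O)cc3)n2)c2ccccc21`, gives 5780 nM
compound 3, `CCn1nc(-c2ccnc(Nc3cccc(O)c3)n2)c2ccccc21`, gives 33500 nM

Compound 2 gives the lowest number of the three, yet the gap is small (a 1.5-fold lower number from compound 1 to compound 2 (0.19 log units; within the scatter)), so compound 1 and compound 2 cannot be ranked; only compound 3 stands clearly apart (a 5.8-fold higher number from compound 2 to compound 3 (0.76 log units; beyond the scatter)).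

Compound 4, `CCCn1nc(-c2ccnc(Nc3ccc(O)cc3)n2)c2ccccc21`, differs from compound 2 by methyl in place of hydrogen on a saturated chain carbon, two bonds along the chain from an aromatic nitrogen. Within the data shown here, the one step that bears on this is the earlier lengthening of the same chain from compound 1 to compound 2, which stayed within the scatter (a 1.5-fold lower number from compound 1 to compound 2 (0.19 log units; within the scatter)). A further methyl on that chain is therefore expected to move the number in this assay by no more than the scatter, in either direction. For compound 4 the estimate is 5000 nM, with a range from 2500 nM to 11000 nM, which corresponds to an expected step of a 1.2-fold lower number from compound 2 to compound 4 (0.06 log units; within the scatter).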

Compound 4, concentration for 50% growth inhibition: 3340 nM
Compound 4: the middle estimate sits 1.5-fold (0.18 log units) above what was measured; the measured number falls inside the stated range.
By their numbers in this assay, from the lowest: compounds 4, 2 and 1 (each within the scatter of the next, the first and the last beyond it); then compound 3.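

In this assay the added methyl alone gives a 1.7-fold lower number from compound 2 to compound 4 (0.24 log units; within the scatter) and so cannot rank the propyl chain against the ethyl chain. Over the full lengthening, a 2.7-fold lower number from compound 1 to compound 4 (0.43 log units; beyond the scatter) is the first step at this position to pass the scatter, so steps too small to read singly can add up to a real gap. Nothing available explains this difference.

Going by these compounds, whether a butyl chain would extend the same run of numbers remains open. So does the effect of an amine at the end of the propyl chain.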